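Working notes: adding a chloro group to compound 2

A few compounds are considered here, and "the series" means these few. Any claim that something is new, unique, unknown or untested is made for them only; others in the source may bear on it.

Measured in an ADME assay on J774.A1 cells (Mus musculus) for cytotoxicity, read by MTT assay, with a stated time of 72 h; a higher number here means that more compound is tolerated, a lower number that less compound is tolerated:
- compound 1 `Fc1ccc(F)c(COC(CCn2ccnc2)c2cccs2)c1`: 15100 nM
- compound 2 `Clc1cccc(COC(CCn2ccnc2)c2cccs2)c1`: 46000 nM
- compound 3 `Clc1cccc(COC(CCn2cncn2)c2ccco2)c1`: 18600 nM

Compound 2 stands highest of the three, with compound 3 and compound 1 both lower beyond the scatter. Compound 4 `Clc1ccc(Cl)c(COC(CCn2ccnc2)c2cccs2)c1` carries chloro in place of hydrogen on an aromatic carbon, ortho to a large group and para to a chloro group: chloro in place of hydrogen on an aromatic carbon. Within the data shown here, no measured pair isolates this change. Among the measured compounds shown here, compound 1, the only measured compound with a further halogen on that ring, gives 15100 nM, but compound 3 is also lower without one, so the guide is weak. The expected step, a 2.2-fold lower number from compound 2 to compound 4 (0.34 log units; beyond the scatter), is a moderate fall in this assay, just beyond the scatter. The estimated value for compound 4 is 21000 nM, with an expected range of 9000 nM to 48000 nM.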

Compound 4, half-maximal cytotoxic concentration: 18000 nM
Compound 4: the middle estimate sits 1.2-fold (0.07 log units) above what was measured; the measured number falls inside the stated range.
By their numbers in this assay, from the lowest: compounds 1, 4 and 3 (each within the scatter of the next); then compound 2.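

Under this assay chloro in place of hydrogen on an aromatic carbon, ortho to a large group and para to a chloro group, gives a 2.6-fold lower number from compound 2 to compound 4 (0.41 log units; beyond the scatter) and is the only single-place change in the series. This position is therefore not silent: one added chloro group lowers the tolerated concentration beyond the scatter, though modestly. Nothing available accounts for this step.

As far as these compounds go, whether a methoxy group or an amine on the same carbon would move the number the same way stays open. So does whether this step holds on the core of compound 3.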